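A few compounds are considered here, and "the series" means these few. Any claim that something is new, unique, unknown or untested is made for them only; others in the source may bear on it.

Compound 2 `C[C@@H](NC1CCN(CCCc2c[nH]c3ccc(-n4cnnc4)cc23)CC1)c1ccccc1` stands with the lowest of the two numbers in a functional assay on CHO cells for activation of 5-hydroxytryptamine receptor 1D (Homo sapiens), read by GTPgammaS binding (on this read-out lower numbers stand for smaller maximal responses and higher numbers for larger maximal responses), where compound 2 gives 90%; its nearest neighbour, compound 1 `OCCC(NC1CCN(CCCc2c[nH]c3ccc(-n4cnnc4)cc23)CC1)c1ccccc1`, gives 100%, and the step of a number 10 percentage points lower from compound 1 to compound 2 (within the scatter) lies within the scatter. Compound 3 `CC(CO)(NC1CCN(CCCc2c[nH]c3ccc(-n4cnnc4)cc23)CC1)c1ccccc1` carries the change (1-(hydroxymethyl)-1-phenylethyl in place of 1-phenylethyl on an amine nitrogen). Among the measured compounds shown here, only that step from compound 1 to compound 2 bears on this change, and it was within the scatter, so no step beyond the scatter is expected in this assay. Compound 3 is therefore estimated to give 90%, between 70% and 105%, an expected step of no change at the digits printed from compound 2 to compound 3 (within the scatter).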

Compound 3, largest response reached (reported as efficacy), in percent of the reference or control that the assay uses: 59%
Compound 3: middle estimate off by 31 percentage points, on the high side, outside the stated range (below it).
By their numbers in this assay, from the lowest: compound 3; then compounds 2 and 1 (each within the scatter of the next).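

In this assay, among the compounds shown here, the group on this amine nitrogen is not indifferent: the response falls by a number 31 percentage points lower from compound 2 to compound 3 (beyond the scatter) and by a number 41 percentage points lower from compound 1 to compound 3 (beyond the scatter), both beyond the scatter, whereas the only earlier step stayed within it. A hydroxyl in the group does not by itself go with the loss, since compound 1 carries 3-hydroxy-1-phenylpropyl and gives 100% in the same assay. No evidence accounts for the drop. Still open, as far as these compounds go, is whether the lower response follows the hydroxymethyl or the second carbon substituent on the benzylic carbon; 1-methyl-1-phenylethyl or 1-(aminomethyl)-1-phenylethyl would bear on that.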